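The compounds below may be only part of what the source reports. "The series", "measured", "known", "first", "only" and "open" are said of these compounds alone.

Measured compounds:
- compound 1, `Cn1ncc2c(=O)n(-c3ccccc3)c(SC(C)(C)c3ccccc3)nc21`: 1900 nM
- compound 2, `Cn1ncc2c(=O)n(-c3ccccc3)c(OCc3cccc(F)c3)nc21`: 775 nM

In an assay on isolated protein for inhibition of aldehyde dehydrogenase 1A1 (Homo sapiens) (on this read-out higher numbers stand for weaker inhibition and lower numbers for stronger inhibition), compound 1 gives 1900 nM and so stands with the highest of the two numbers. Compound 2 gives 775 nM, a lower number; the gap between compound 2 and compound 1 lies beyond the scatter of this kind of measurement.

Compound 3, `CC(Sc1nc2c(cnn2C)c(=O)n1-c1ccccc1)c1cccnc1`, has not yet been measured in this assay. It differs from compound 1 in one place: 1-(pyridin-3-yl)ethyl in place of 1-methyl-1-phenylethyl on a sulfur. Within the data shown here, no measured pair shows this change, so there is no step to lean on, and neither the data on compound 1 nor those on compound 2 say how the shared core responds to such a swap on the sulfur. The step from compound 1 to compound 3 is therefore expected to be small, likely within the scatter in either direction, and the estimated step of a 1.3-fold lower number from compound 1 to compound 3 (0.10 log units; within the scatter) reflects that. For compound 3 the expected value in this assay is 1500 nM, with a range from 400 nM to 6000 nM.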

Compound 3, half-maximal inhibitory concentration: 139 nM
Estimate against measurement, compound 3: 11-fold (1.03 log units) above, outside the stated range (below it).
By their numbers in this assay, from the lowest: compound 3; then compound 2; then compound 1.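

In this assay, the group on the sulfur turns out to matter a great deal: 1-(pyridin-3-yl)ethyl in place of 1-methyl-1-phenylethyl gives a 14-fold lower number from compound 1 to compound 3 (1.14 log units; beyond the scatter), a size of change at this position that the earlier values could not reveal. The change is not a simple one, as the entering group brings a ring with a hetero atom and a hydrogen-bond acceptor and has fewer heavy atoms than the group it replaces. Nothing available here accounts for the size of this step.

Going by these compounds, what stays open is which part of the swap carries the effect, the ring nitrogen or the change in the chain on the sulfur. A 1-phenylethyl group on the sulfur, or a 1-(pyridin-4-yl)ethyl group, would bear on that question, and the compounds shown include neither.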